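The source may hold more compounds than are shown below. What is called first, only, known or untested is meant among the compounds shown, and "the series" means these compounds.

Measured so far:
Compound 1, `O=S(=O)(/C=C/c1ccccn1)c1ccccc1F`: 1050 nM
Compound 2, `O=S(=O)(/C=C/c1ccc(Cl)cn1)c1ccccc1F`: 1040 nM

Both numbers come from an assay on U2OS cells for activation of nuclear factor erythroid 2-related factor 2 (Homo sapiens), read by beta-arrestin recruitment, with a stated time of 6 h; on this read-out lower numbers stand for an effect already at smaller amounts and higher numbers for an effect only at larger amounts of compound. Within the data shown here, on these two numbers compound 1 stands level with its only neighbour: the step of a 1.0-fold lower number from compound 1 to compound 2 (0.00 log units; within the scatter) is within the scatter, so neither compound can be called more or less potent than the other.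

Compound 3, `O=S(=O)(/C=C/c1ccccn1)c1ccccc1Cl`, has not yet been measured. It differs from compound 1 by chloro in place of fluoro on an aromatic carbon. Among the measured compounds shown here, only one measured step exists, a 1.0-fold lower number from compound 1 to compound 2 (0.00 log units; within the scatter), and that concerns chloro entering elsewhere in the molecule, so it bears only loosely on this change; it showed no shift beyond the scatter. For the measured compounds named here, no measured pair swaps fluoro for chloro at the place in question. With no indication of a shift either way, the step expected from compound 1 to compound 3 is a 1.1-fold lower number from compound 1 to compound 3 (0.02 log units; within the scatter), that is, none beyond the scatter. Compound 3 is therefore estimated at 1000 nM, with a range from 450 nM to 2500 nM.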

Compound 3, half-maximal effective concentration: 618 nM
Estimate against measurement, compound 3: 1.6-fold (0.21 log units) above; the range from low to high includes it.
By their numbers in this assay, from the lowest: compounds 3, 2 and 1 (each within the scatter of the next).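

Exchanging fluoro for chloro on this aromatic carbon, ortho to a large group, gives a 1.7-fold lower number from compound 1 to compound 3 (0.23 log units; within the scatter) in this assay. Among these compounds, the earlier compounds showed only chloro entering elsewhere in the molecule, so this is the first reading at this position, and on it the two halogens cannot be told apart. No supporting data bear on how either halogen acts at this place.

From the compounds shown here alone, it remains open whether this position would respond to a group other than a halogen, such as a methoxy group, an amine or a carboxylic acid, with a step beyond the scatter. Also open, going by these compounds, is what a single compound would show with chloro both at this place and at the place it occupies in compound 2.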